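The compounds below may be only part of what the source reports. "The series", "measured", "known", "first", "only" and "open" are said of these compounds alone.

Measured in a functional assay on QGY-7703 cells (Homo sapiens) for cytotoxicity, read by MTT assay, with a stated time of 24 h; a higher number here means a weaker inhibitor, a lower number a stronger inhibitor:
- compound 1 `O=C1/C(=C/c2cccnc2)CN(S(=O)(=O)c2ccc(F)cc2)C/C1=C\c1ccccc1F`: 15300 nM
- compound 2 `O=C1/C(=C/c2cccnc2)CNC/C1=C\c1ccccc1C(F)(F)F`: 3800 nM
- compound 3 `Cc1ccc(S(=O)(=O)N2C/C(=C\c3cccnc3)C(=O)/C(=C/c3ccccc3C(F)(F)F)C2)cc1`: 6170 nM

Of these three numbers, compound 1 has the highest, at 15300 nM, which is clearly separated from compound 3 at 6170 nM. Compound 3 lies closest to compound 2, and the measured step is a 1.6-fold higher number from compound 2 to compound 3 (0.21 log units; within the scatter).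

The next compound, compound 4 `O=C1/C(=C/c2cccnc2)CN(S(=O)(=O)c2ccc(F)cc2)C/C1=C\c1ccccc1C(F)(F)F`, differs from compound 3 by one substitution: fluoro in place of methyl on an aromatic carbon. This turns the (4-methylphenyl)sulfonyl group into (4-fluorophenyl)sulfonyl. Among the compounds with values here, no measured step makes this exchange directly. The nearest evidence is a 1.6-fold higher number from compound 2 to compound 3 (0.21 log units; within the scatter), where the whole (4-methylphenyl)sulfonyl group replaces hydrogen on an amine nitrogen in a ring. Compound 1 carries the (4-fluorophenyl)sulfonyl group too, but it also differs from compound 4 elsewhere, so it gives only a weak hint towards a higher number.

In this assay, no change beyond the scatter is therefore expected, and the expected step is a 1.1-fold higher number from compound 3 to compound 4 (0.04 log units; within the scatter). The estimated value for compound 4 is 6800 nM, with an expected range of 3000 nM to 15000 nM.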

Compound 4, half-maximal inhibitory concentration: 6030 nM
Compound 4: the middle estimate sits 1.1-fold (0.05 log units) above what was measured; the range from low to high includes it.
By their numbers in this assay, from the lowest: compounds 2, 4 and 3 (each within the scatter of the next); then compound 1.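

In this assay, fluoro in place of methyl on an aromatic carbon, para to a large group, leaves the number unchanged within the scatter (a 1.0-fold lower number from compound 3 to compound 4 (0.01 log units; within the scatter)), and the (4-fluorophenyl)sulfonyl group likewise stays within the scatter of the free ring amine (a 1.6-fold higher number from compound 2 to compound 4 (0.20 log units; within the scatter)), as the (4-methylphenyl)sulfonyl group did (a 1.6-fold higher number from compound 2 to compound 3 (0.21 log units; within the scatter)). The one step beyond the scatter among these new comparisons lies in the other changed place, where trifluoromethyl stands in place of fluoro on an aromatic carbon (a 2.5-fold lower number from compound 1 to compound 4 (0.40 log units; beyond the scatter)). No measurement shown here accounts for any of these steps.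

Going by these compounds, whether an amine or a carboxylic acid at the para place of the sulfonyl-bearing phenyl ring would stay equally close remains open. So does whether the trifluoromethyl-for-fluoro step would hold with the (4-methylphenyl)sulfonyl group.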